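Cytotoxicity in the shared core: a chloro substituent enters

The source may hold more compounds than are shown below. What is called first, only, known or untested is meant among the compounds shown, and "the series" means these compounds.

Compound 1 `CN1CCN(CCNCc2cn(-c3ccc(F)cc3F)nc2-c2ccc(OC(F)(F)F)cc2)CC1` gives 18000 nM in an ADME assay on Huh-7 cells (Homo sapiens) for cytotoxicity; a higher number here means that more compound is tolerated, a lower number that less compound is tolerated. Compound 2 `COC(=O)c1ccc(-c2nn(-c3ccc(F)cc3F)cc2CNCCN2CCN(C)CC2)cc1` gives > 20000 nM in this assay, which is a limit of the assay and not a number.

Compound 2 therefore stands only at the limit of > 20000 nM in this assay, at which 1 of the 2 values shown sits. Compound 3 `CN1CCN(CCNCc2cn(-c3ccc(F)cc3F)nc2-c2ccc(Cl)cc2)CC1` differs from it by chloro in place of methoxycarbonyl on an aromatic carbon. Among the compounds with values here, the one measured step at this position, an at least 1.1-fold higher number from compound 1 to compound 2 (0.04 log units; that floor lies within the scatter), stays within the scatter, so no shift beyond the scatter is expected in this assay. Compound 3 is accordingly estimated at 20000 nM, between 9000 nM and 45000 nM, a step of a number no higher from compound 2 to compound 3 (the limit leaves the size open) that may again end at the limit.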

Compound 3, half-maximal cytotoxic concentration: 19000 nM
Compound 3: the middle estimate sits 1.1-fold (0.02 log units) above what was measured; low and high end bracket the measured number.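

With chloro, a single heavy atom, in place of trifluoromethoxy on the aromatic carbon, this assay gives a 1.1-fold higher number from compound 1 to compound 3 (0.02 log units; within the scatter), so this pair of compounds with real numbers shows no shift beyond the scatter. From the compounds shown here alone, the comparison with methoxycarbonyl reads an at least 1.0-fold lower number from compound 2 to compound 3 (0.02 log units; that floor lies within the scatter), and its size stays open. Compound 2 rests on a limit of the assay and not on a number: the limit of > 20000 nM in this assay, at which 1 of the 3 values shown sits.

Going by these compounds, how far compound 2 lies past that limit remains open. So does the outcome with an amine or a carboxylic acid at this position.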